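Changing the Ring on the Aromatic Nitrogen

The source may report more compounds than this note shows. Statements on the series, on what has been measured and on what is new or still open speak of the compounds shown alone.

Measured compounds in a functional assay on BGC-823 cells (Homo sapiens) for cytotoxicity, read by MTT assay; a lower number here means a stronger inhibitor, a higher number a weaker inhibitor:
compound 1, `Cc1ccccc1Nc1nc(C)c(C(=O)/C=C/c2ccc(Cl)cc2)s1`, where compound 1 gives > 25000 nM
compound 2, `COc1cc(/C=C/C(=O)c2sc(Nc3cccc(Cl)c3)nc2C)cc(OC)c1OC`, where compound 2 gives 11600 nM

The value for compound 1 is a limit of this assay, not a number, as noted in the limit of > 25000 nM in this assay, at which 1 of the 2 values shown sits. Among the compounds with values here, compound 2 is therefore the only compound with a measured number in this assay, and it is a weak inhibitor there. Within the data shown here, compounds 1 and 2 differ in two places, so no single step connects them.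

Compound 3, `COc1cc(/C=C/C(=O)c2sc(Nc3ccccc3C)nc2C)cc(OC)c1OC`, has not yet been measured. It differs from compound 2 in one place: 2-methylphenyl in place of 3-chlorophenyl on a nitrogen on an aromatic ring. Compound 1 carries the same 2-methylphenyl group on that nitrogen but differs elsewhere, so it only loosely hints at the outcome.

The expected step from compound 2 to compound 3 is a 1.9-fold higher number from compound 2 to compound 3 (0.28 log units; within the scatter), a loss of potency beyond the usual scatter, because compound 1 with the 2-methylphenyl group sits at the limit in the limit of > 25000 nM in this assay, at which 1 of the 2 values shown sits. Compound 3 is thus estimated at 22000 nM in this assay, within a range of 7000 nM to 70000 nM.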

Compound 3, half-maximal inhibitory concentration: 5400 nM
Compound 3: middle estimate off by 4.1-fold (0.61 log units), on the high side, outside the stated range (below it).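

In this assay, swapping the group on this nitrogen gives a real if modest gain, with a 2.1-fold lower number from compound 2 to compound 3 (0.33 log units; beyond the scatter), so 2-methylphenyl is better here than 3-chlorophenyl when the rest of the molecule stays the same. Within the data shown here, this is the first direct reading at this position, and it shows that the 2-methylphenyl group can sit on a compound that gives a measured number in this assay, which compound 1 alone could not show. Compound 1, which carries the same 2-methylphenyl group, still gives only a limit and not a number: the limit of > 25000 nM in this assay, at which 1 of the 3 values shown sits.

The single step changes both the group on the ring, methyl for chlorine, and its numbered place, so the compounds shown cannot separate those two changes or say why the number moved. They also leave open how this nitrogen would respond to a longer chain in place of the aromatic ring, or to a phenyl ring carrying an amine or a carboxylic acid.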